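Taking the 3,4-dihydroxyphenyl group off compound 2

The source may hold more compounds than are shown below. What is called first, only, known or untested is meant among the compounds shown, and "the series" means these compounds.

Compound 1 `COc1cc(C2CC(c3cc4ccccc4o3)=NN2C(=O)Nc2ccc([N+](=O)[O-])cc2)ccc1O`: 113000000 nM
Compound 2 `COc1cc(C2CC(c3cc4ccccc4o3)=NN2C(=O)Nc2ccc(O)c(O)c2)ccc1O`: 11000000 nM

In a functional assay on microsomes from liver (Rattus norvegicus, strain Wistar) for inhibition, with a stated time of 15 min (on this read-out lower numbers stand for stronger inhibition and higher numbers for weaker inhibition), compound 2 holds the lower of the two numbers, at 11000000 nM. Compound 3 `COc1cc(C2CC(c3cc4ccccc4o3)=NN2C(=O)Nc2ccc(C)cc2)ccc1O` keeps the core of compound 2 and carries 4-methylphenyl in place of 3,4-dihydroxyphenyl on an amide-type nitrogen. Among the measured compounds shown here, only one measured step bears on this change, and it sits at the same place: a 10-fold lower number from compound 1 to compound 2 (1.01 log units; beyond the scatter). That step brought the 3,4-dihydroxyphenyl group in, and the new change takes it out, so a higher number is expected in this assay. For the measured compounds named here, no measured compound carries 4-methylphenyl, so how much of that large step returns remains open, and only part of it is assumed. The expected change is a 3.6-fold higher number from compound 2 to compound 3 (0.56 log units; beyond the scatter). The estimate for compound 3 is 40000000 nM, with an expected range from 12000000 nM to 130000000 nM.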

Compound 3, half-maximal inhibitory concentration: 44000000 nM
Compound 3: middle estimate off by 1.1-fold (0.04 log units), on the low side; the measured number falls inside the stated range.
By their numbers in this assay, from the lowest: compound 2; then compound 3; then compound 1.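

In this assay the place on the amide-type nitrogen now has three groups that can be set in order, and 4-methylphenyl falls clear of both the others. Putting it in place of 3,4-dihydroxyphenyl gives a 4.0-fold higher number from compound 2 to compound 3 (0.60 log units; beyond the scatter) and so gives back part of the earlier gain, while methyl in place of nitro on an aromatic carbon gives a 2.6-fold lower number from compound 1 to compound 3 (0.41 log units; beyond the scatter) and shows that the 4-nitrophenyl compound is not merely the baseline for any change at this place. No measurement on hand accounts for this order.

On these data alone, whether one hydroxyl of the 3,4-dihydroxyphenyl group would be enough to keep the lower number of compound 2 stays open. So does where an amine or a carboxylic acid on the phenyl ring would fall in this order.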